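The source may report more compounds than this note shows. Statements on the series, on what has been measured and on what is new or still open speak of the compounds shown alone.

Measured so far in a functional assay on RS4-11 cells (Homo sapiens) for inhibition, read by CCK-8 assay, with a stated time of 48 h, tested at 20 uM (on this read-out higher numbers stand for more inhibition of growth at the one concentration tested and lower numbers for less inhibition of growth), are three compounds
Compound 1 (`COc1ccc(S(=O)(=O)Oc2ccccc2/C=C(\C#N)C(=O)Nc2nnc(-c3cccs3)s2)cc1`) gives 76%
Compound 2 (`N#C/C(=C\c1ccccc1OS(=O)(=O)c1ccc([N+](=O)[O-])cc1)C(=O)Nc1nnc(-c2cccs2)s1`) gives 40%
Compound 3 (`Cc1ccc(S(=O)(=O)Oc2ccccc2/C=C(\C#N)C(=O)Nc2nnc(Cc3cccc4ccccc34)s2)cc1`) gives 73%

Compound 1 shares the top of this small set with compound 3, as the two values lie within the scatter of each other. Compound 2 stands well apart from compound 1, and the gap is a number 36 percentage points lower from compound 1 to compound 2 (beyond the scatter) in size.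

Compound 4 (`COc1ccc(S(=O)(=O)Oc2ccccc2/C=C(\C#N)C(=O)Nc2nnc(Cc3ccccc3)s2)cc1`) has not yet been measured. It keeps the core of compound 1 and carries benzyl in place of thiophen-2-yl on an aromatic carbon. Within the data shown here, the one measured single change, a number 36 percentage points lower from compound 1 to compound 2 (beyond the scatter) again, is nitro in place of methoxy at another place, so it gives no direct measure of this swap. Compound 3 also lacks thiophen-2-yl at this place, although it differs from compound 1 at a second place too, and the value of compound 3 (73%) remains within the scatter of compound 1. On that basis, no change beyond the scatter is expected in this assay for the swap. The expected change is small (a number 6 percentage points lower from compound 1 to compound 4 (within the scatter)). For compound 4 the estimated value is 70% (expected range 52% to 84%).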

Compound 4, percent growth inhibition at one concentration: 78%
Beside the measured number, compound 4's estimate is 8 percentage points below it; the measured number falls inside the stated range.
By their numbers in this assay, from the lowest: compound 2; then compounds 3, 1 and 4 (each within the scatter of the next).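

Read as a single change in this assay, the swap gives a number 2 percentage points higher from compound 1 to compound 4 (within the scatter) and so shows what compound 3, which differs from compound 1 at a second place too, could not show: the effect of this one replacement with the rest of compound 1 held fixed. On an aromatic carbon of the five-membered aromatic ring with 2 nitrogen and 1 sulfur, benzyl, with 7 heavy atoms and 0 hydrogen-bond acceptors, takes the place of thiophen-2-yl, with 5 heavy atoms and 1 hydrogen-bond acceptor, with no change beyond the scatter, so in this one pair the sulfur-bearing ring is not needed to keep the number at this level. Nothing available explains why the number holds across this swap.

The compounds shown leave open whether a group of another kind at this place, such as an amine, a carboxylic acid or a longer chain, would hold the number as benzyl does. They also leave open whether the swap would read the same with nitro in place of methoxy, the change that gave a number 36 percentage points lower from compound 1 to compound 2 (beyond the scatter), and, with only one concentration tested, whether compound 1 and compound 4 would separate at other concentrations.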